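Swapping the Amide Substituent and Expected Cytotoxicity

The compounds below may be only part of what the source reports. "The series", "measured", "known", "first", "only" and "open" are said of these compounds alone.

Compound 2 `Cc1cc(C)cc(S(=O)(=O)c2c(C(=O)NC(c3ccc(Cl)cc3)C3CC3)[nH]c3ccc(Cl)cc23)c1` shares its core with compound 1 `Cc1cc(C)cc(S(=O)(=O)c2c(C(=O)NCC(=O)NC(C)c3ccncc3)[nH]c3ccc(Cl)cc23)c1`. In an ADME assay on MT4 cells (Homo sapiens) for cytotoxicity, read by MTT assay (on this read-out lower numbers stand for higher toxicity in this test and higher numbers for lower toxicity in this test), compound 1 gives 47000 nM. For compound 2 this assay reports > 47300 nM, which is a limit of the assay and not a number. The step of a number no lower from compound 1 to compound 2 (the limit leaves the size open) therefore cannot be sized, as the limit of > 47300 nM in this assay, at which 1 of the 2 values shown sits, shows. Compound 3 `Cc1cc(C)cc(S(=O)(=O)c2c(C(=O)NC(C)c3ccccc3F)[nH]c3ccc(Cl)cc23)c1` has not yet been measured. It differs from compound 2 in one place: a group of 9 heavy atoms (8 carbon, 1 fluorine; one six-membered aromatic ring of carbon only) in place of a group of 11 heavy atoms (10 carbon, 1 chlorine; one three-membered non-aromatic ring of carbon only, one six-membered aromatic ring of carbon only), on an amide-type nitrogen. Going by the values given here, the only measured step in this set also altered the group on the amide-type nitrogen, and it left the value no lower, but its size is unreadable, so it gives little guide to how far a further change at that position moves the read-out. Compound 1 already shows low toxicity in this assay, and compound 3 keeps the shared core with a group of similar kind. The step of an at least 1.0-fold lower number from compound 2 to compound 3 (0.02 log units; that floor lies within the scatter) is therefore expected to stay within the scatter. The estimate for compound 3 in this assay is 45000 nM, between 15000 nM and 120000 nM, and the result may again be reported only as a limit.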

Compound 3, half-maximal cytotoxic concentration: > 51500 nM
Compound 3: no number, only a limit (the forecaster's own chance of this, stated with the estimate: 60%); at least 1.1-fold (0.05 log units) between middle value and limit.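

Going by these compounds alone, compound 3 is again reported only as a limit of the assay and not as a number: the limit of > 51500 nM in this assay, at which 1 of the 3 values shown sits. In this assay, the change from the group of compound 1 to 1-(2-fluorophenyl)ethyl on the amide-type nitrogen gives an at least 1.0-fold higher number from compound 1 to compound 3 (0.03 log units; that floor lies within the scatter), so this swap shows no step that can be told from ordinary repeat variation. What compound 3 adds is a third, differently built group at this position, with a fluorine in place of the chlorine and no three-membered ring, and this group also gives no number that can be placed on a scale. The step between compound 2 and compound 3 cannot be read, as both sides are limits.

On these data alone, how far compound 2 and compound 3 lie past their limits stays open, and so does the order among the three compounds. Also open, as far as these compounds go, is whether a group carrying a primary amine or a carboxylic acid on the amide-type nitrogen would bring the read-out down to a measurable number.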